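A few compounds are considered here, and "the series" means these few. Any claim that something is new, unique, unknown or untested is made for them only; others in the source may bear on it.

Working notes on three compounds measured in an ADME assay on Vero cells (Chlorocebus sabaeus) for cytotoxicity, read by MTT assay, with a stated time of 72 h (on this read-out lower numbers stand for stronger inhibition and higher numbers for weaker inhibition), and on a fourth not yet tested. Compound 1 `O=C(c1ccncc1)N1N=C(c2cc3ccccc3o2)CC1c1ccccc1O` gives in this assay only a limit, > 195000 nM. Compound 2 `O=C(c1ccncc1)N1N=C(c2cc3ccccc3o2)CC1c1ccc(Cl)cc1` gives in this assay only a limit, > 220000 nM. Compound 3 `CCn1cc(C(=O)N2N=C(c3cc4ccccc4o3)CC2c2ccccc2C(=O)O)c(=O)c2ccc(C)nc21` gives in this assay only a limit, > 196000 nM. Every value shown is a limit (the limit of > 195000 nM in this assay, at which 1 of the 3 values shown sits, (the limit of > 196000 nM in this assay, at which 1 of the 3 values shown sits), (the limit of > 220000 nM in this assay, at which 1 of the 3 values shown sits)), so compound 3 stands with the other two and no ordering among them can be drawn. The step that the two limits leave unreadable from compound 1 to compound 2 cannot be read, both ends being limits.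

Compound 4 `CCn1cc(C(=O)N2N=C(c3cc4ccccc4o3)CC2c2ccc(Cl)cc2)c(=O)c2ccc(C)nc21` differs from compound 3 by 4-chlorophenyl in place of 2-carboxyphenyl on a saturated ring carbon. Within the data shown here, the only measured step touching the same ring carbon, from compound 1 to compound 2, is unreadable, so it gives no size to carry over. No step beyond the scatter is expected, the estimated step being a step that the limit leaves unreadable from compound 3 to compound 4. Compound 4 is expected to give in this assay about 220000 nM, within 120000 nM to 450000 nM, most likely reported again as a limit.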

Compound 4, half-maximal inhibitory concentration: > 160000 nM
Compound 4 was reported as a limit; the forecaster's own chance of this, stated with the estimate: 85%; the middle value does not contradict the limit.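

In this assay compound 4 gives only a limit, > 160000 nM. Compound 3 also gives only a limit, > 196000 nM. No step can be read between compound 3 and compound 4. The compounds shown leave open whether any change among them shifts the read-out in this assay at all.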